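Furan-2-yl for 2-chlorophenyl: the step to compound 3

The compounds below may be only part of what the source reports. "The series", "measured", "known", "first", "only" and "open" are said of these compounds alone.

Of the compounds shown here, two have been read in a functional assay on MCF7 cells (Homo sapiens) for antiproliferative activity, read by MTT assay, with a stated time of 72 h; on this read-out higher numbers stand for weaker inhibition and lower numbers for stronger inhibition. Compound 1 `CCCSc1nc(N/N=C/c2ccc(Cl)cc2)c2nnn(Cc3ccccc3)c2n1` gives > 64000 nM, which is a limit of the assay and not a number. Compound 2 `CCCSc1nc(N/N=C(\C)c2ccccc2O)c2nnn(Cc3ccccc3Cl)c2n1` gives > 64000 nM in this assay, again a limit and not a number. Both readings sit at the limit of > 64000 nM in this assay, at which 2 of the 2 values shown sit, so compound 2 stands no differently from compound 1 on what has been measured, and neither can be placed in order against the other.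

Compound 3 `CCCSc1nc(N/N=C(\C)c2ccccc2O)c2nnn(Cc3ccco3)c2n1` is the next member to be measured. Its difference from compound 2 is furan-2-yl in place of 2-chlorophenyl on a saturated chain carbon bound to an aromatic nitrogen. Within the data shown here, no measured step between compounds is available to calibrate this change, and two limits give no foothold for a direction. The step that the limit leaves unreadable from compound 2 to compound 3 is expected to be none beyond the scatter. For compound 3 in this assay the estimate is 80000 nM, in a range from 20000 nM to 300000 nM, and the most likely outcome is that compound 3 is again reported only as a limit.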

Compound 3, half-maximal inhibitory concentration: 29000 nM
Estimate against measurement, compound 3: 2.8-fold (0.44 log units) above; the range from low to high includes it.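

In this assay, furan-2-yl in place of 2-chlorophenyl on a saturated chain carbon bound to an aromatic nitrogen gives an at least 2.2-fold lower number from compound 2 to compound 3 (0.34 log units; beyond the scatter). Among these compounds, this position is therefore not silent: with the rest of compound 2 held, a change in this one place separates the pair, and compound 3 at 29000 nM carries the only reading of the three that is a number. The step is a bound with no upper end, and its full size cannot be read because compound 2 stands at a limit: the limit of > 64000 nM in this assay, at which 2 of the 3 values shown sit.

Going by these compounds, whether this shift belongs to furan-2-yl itself or would also follow from another group at this place, such as an amine, a carboxylic acid or a longer chain, remains open. Compound 1 differs from compound 3 in more than one place, so it gives no further reading of this change, and the series still lacks a second numerical value against which to size the step from the 2-chlorophenyl member.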